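Hydroxyl for methyl on the cyclohexyl amide substituent

The compounds below may be only part of what the source reports. "The series", "measured", "known", "first", "only" and "open" are said of these compounds alone.

Compound 2 `Cc1cc(C)c2cc(C(=O)N[C@@H]3CCCC[C@@H]3C)[nH]c2c1` is known in a physicochemical assay for solubility, measured as thermodynamic solubility, with a stated time of 24 h, at pH 6.8 (on this read-out lower numbers stand for lower solubility and higher numbers for higher solubility), only as a limit, < 4000 nM; this is the limit of < 4000 nM in this assay, at which 1 of the 2 values shown sits. For the measured compounds named here, compound 1 `CCC(C)NC(=O)c1cc2c(C)cc(C)cc2[nH]1` gives 22000 nM in this assay, and the one measured step, an at least 5.5-fold lower number from compound 1 to compound 2 (0.74 log units; beyond the scatter), concerns the exchange of sec-butyl for 2-methylcyclohexyl, not the change now at hand. Compound 3 `Cc1cc(C)c2cc(C(=O)NC3CCCCC3O)[nH]c2c1` differs from compound 2 by 2-hydroxycyclohexyl in place of 2-methylcyclohexyl on an amide-type nitrogen. Going by the values given here, no measured step covers this exchange, and the limit for compound 2 leaves its own position open. For compound 3 the step of an at least 3.7-fold higher number from compound 2 to compound 3 (0.57 log units; beyond the scatter) is expected, upward. Compound 3 is estimated at 15000 nM, within 3000 nM to 80000 nM.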

Compound 3, solubility: 56000 nM
Estimate against measurement, compound 3: 3.7-fold (0.57 log units) below; low and high end bracket the measured number.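

In this assay, a ring on the amide-type nitrogen does not by itself go with a low number: 2-hydroxycyclohexyl in place of 2-methylcyclohexyl gives an at least 14-fold higher number from compound 2 to compound 3 (1.14 log units; beyond the scatter). Set against sec-butyl, the same ring gives a 2.5-fold higher number from compound 1 to compound 3 (0.41 log units; beyond the scatter), so the drop seen with 2-methylcyclohexyl does not hold for this ring. Compound 2 is known only as a limit: the limit of < 4000 nM in this assay, at which 1 of the 3 values shown sits.

Going by these compounds, the full size of the step to compound 3 therefore stays open. Also open, on these data alone, is how a methoxy group or an amine would read in place of the hydroxyl on this ring.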